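Methoxy for tert-butylphenyl, transferred to the second core

The source may report more compounds than this note shows. Statements on the series, on what has been measured and on what is new or still open speak of the compounds shown alone.

Compound 1 `CC(C)(C)c1ccc(-c2ccc(OCc3ccccc3)c(/C=C3\SC(=S)NC3=O)c2)cc1` gives 2000 nM in a functional assay on A549 cells (Homo sapiens) for inhibition, read by sulforhodamine B assay; a higher number here means a weaker inhibitor of growth, a lower number a stronger inhibitor of growth. Compound 2 `COc1ccc(OCc2ccccc2)c(/C=C2\SC(=S)NC2=O)c1` gives 7000 nM in this assay, and the step of a 3.5-fold higher number from compound 1 to compound 2 (0.54 log units; beyond the scatter) belongs to the change (methoxy in place of 4-(tert-butyl)phenyl on an aromatic carbon). Compound 3 `CC(C)(C)c1ccc(-c2ccc(OCc3ccccc3)c(/C=C3\SC(=O)NC3=O)c2)cc1` gives 2000 nM in this assay; the two cores differ by a group of 8 heavy atoms (4 carbon, 1 nitrogen, 2 oxygen, 1 sulfur; one five-membered non-aromatic ring with 2 hetero atoms) in place of a group of 8 heavy atoms (4 carbon, 1 nitrogen, 1 oxygen, 2 sulfur; one five-membered non-aromatic ring with 2 hetero atoms), on an aromatic carbon, and the step of no change at the digits printed from compound 1 to compound 3 (within the scatter) shows that swapping the core does not move the number. Within the data shown here, compound 4 `COc1ccc(OCc2ccccc2)c(/C=C2\SC(=O)NC2=O)c1` is not yet measured; it differs from compound 3 by methoxy in place of 4-(tert-butyl)phenyl on an aromatic carbon, the same change as the one from compound 1 to compound 2, at the same place. Among the measured compounds shown here, the expected step of a 3.5-fold higher number from compound 3 to compound 4 (0.54 log units; beyond the scatter) is set beside the measured one because a 3.5-fold higher number from compound 1 to compound 2 (0.54 log units; beyond the scatter) is the only reading of this change at hand, and because no change at the digits printed from compound 1 to compound 3 (within the scatter) shows the two cores level before the change. Compound 4 is therefore expected to give about 7000 nM in this assay, with a range of 3500 nM to 14000 nM allowing for the usual spread of repeated measurements. A single prior step is a thin basis; the measurement will show whether the change carries over.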

Compound 4, concentration for 50% growth inhibition: 14000 nM
Estimate against measurement, compound 4: 2.0-fold (0.30 log units) below, and the stated range covers the measured number.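

On the second core, methoxy in place of 4-(tert-butyl)phenyl again weakens growth inhibition in this assay, giving a 7.0-fold higher number from compound 3 to compound 4 (0.85 log units; beyond the scatter) and so matching the direction seen on the first core, and the two readings do not differ: the same change on two cores in this assay, a 3.5-fold higher number (0.54 log units; beyond the scatter) from compound 1 to compound 2 and a 7.0-fold higher number (0.85 log units; beyond the scatter) from compound 3 to compound 4, 2.0-fold (0.30 log units) apart, within the scatter of two such steps. With methoxy in place, the core swap gives a 2.0-fold higher number from compound 2 to compound 4 (0.30 log units; within the scatter) and so leaves the two cores level, as they were with 4-(tert-butyl)phenyl: the same change on two cores in this assay, no change at the digits printed (within the scatter) from compound 1 to compound 3 and a 2.0-fold higher number (0.30 log units; within the scatter) from compound 2 to compound 4, 2.0-fold (0.30 log units) apart, within the scatter of two such steps. This shows that the change carried over between these two cores in this one assay, but two pairs cannot show that it would carry to any further core, and they do not show why the number moves.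

Open, on these data alone, is how groups other than these two would read at this aromatic carbon in this assay, for example an amine, a carboxylic acid or a longer alkoxy chain. Also open, as far as these compounds go, is whether the agreement between the cores holds when the benzyloxy group is replaced.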